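A few compounds are considered here, and "the series" means these few. Any claim that something is new, unique, unknown or untested is made for them only; others in the source may bear on it.

Measured in a functional assay on MCF7 cells (Homo sapiens) for inhibition, read by MTT assay, with a stated time of 48 h; a higher number here means a weaker inhibitor, a lower number a stronger inhibitor:
compound 1 `O=C(CC(c1ccc(Cl)cc1)C(C(=O)Nc1ccccn1)C(=O)Nc1ccccn1)c1ccc(F)cc1`: 21200 nM
compound 2 `O=C(CC(c1ccc([N+](=O)[O-])cc1)C(C(=O)Nc1ccccn1)C(=O)Nc1ccccn1)c1ccccc1`: "not active" (no number reported)

Both compounds share the same core, but only compound 1 gave a number. Compound 2 has no single value and is reported only as "not active" (no number reported), so it has no exact place on the scale.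

Compound 3 `Cc1cc(C)c(C(CC(=O)c2ccccc2)C(C(=O)Nc2ccccn2)C(=O)Nc2ccccn2)c(C)c1` has not yet been measured. The structural change is 2,4,6-trimethylphenyl in place of 4-nitrophenyl on a saturated chain carbon bound to two saturated chain carbons. The six-membered aromatic ring of carbon only stays, while the groups on it differ.

With no number for compound 2, the size of this step cannot be calculated. No large gain in potency is expected in this assay. The closest numerical guide is compound 1 at 21200 nM, so compound 3 is expected to be a weak inhibitor of similar order, with a real chance that it too gives no number. For compound 3, the estimated value is 30000 nM, with an expected range from 10000 nM to 90000 nM.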

Compound 3, half-maximal inhibitory concentration: 28800 nM
Compound 3: the middle estimate sits 1.0-fold (0.02 log units) above what was measured; measured number inside the range.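

In this assay, going by these compounds alone, compound 3 gives 28800 nM, but compound 2 has no number, so no step between compound 2 and compound 3 can be read. The compounds shown leave open how much 2,4,6-trimethylphenyl in place of 4-nitrophenyl changes potency. Nothing available here explains the value of compound 3.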